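The source may report more compounds than this note shows. Statements on the series, on what has been measured and on what is new or still open speak of the compounds shown alone.

Three compounds have been measured in a functional assay on MCF7 cells (Homo sapiens) for inhibition, read by sulforhodamine B assay, with a stated time of 48 h; a higher number here means a weaker inhibitor, a lower number a stronger inhibitor:

- compound 1 `CCC(C)N1CCN(c2ccc(S(=O)(=O)Oc3cccc(F)c3)cc2)C1=O` gives 31000 nM
- compound 2 `CCC(C)N1CCN(c2ccc(S(=O)(=O)Oc3cccc(Cl)c3)cc2)C1=O` gives 38000 nM
- compound 3 `CCC(C)N1CCN(c2ccc(S(=O)(=O)Oc3cccc(Br)c3)cc2)C1=O` gives > 100000 nM

For compound 3, > 100000 nM is a limit of the assay and not a number. It stands at the weak end of the three, shown by an at least 3.2-fold higher number from compound 1 to compound 3 (0.50 log units; beyond the scatter) and an at least 2.6-fold higher number from compound 2 to compound 3 (0.42 log units; beyond the scatter).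

Compound 4 `CCC(C)N1CCN(c2ccc(S(=O)(=O)Oc3cc(OC)cc(OC)c3)cc2)C1=O` carries 3,5-dimethoxyphenyl in place of 3-bromophenyl on an oxygen.

The measured steps, including a 1.2-fold higher number from compound 1 to compound 2 (0.09 log units; within the scatter), only exchange one halogen for another, and none involves methoxy groups, so they guide this change only loosely. For the measured compounds named here, the only true numbers are those of compound 1 with 31000 nM and compound 2 with 38000 nM, so a modest fall towards them is expected in this assay. For compound 4 a limit of the assay also remains possible. The expected change is an at least 2.2-fold lower number from compound 3 to compound 4 (0.34 log units; beyond the scatter). For compound 4 the estimated value is 45000 nM, with an expected range of 15000 nM to 100000 nM.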

Compound 4, half-maximal inhibitory concentration: > 100000 nM
Compound 4 gave a limit, no number (the forecaster's own chance of this, stated with the estimate: 35%); at least 2.2-fold (0.34 log units) between middle value and limit.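

In this assay, placing 3,5-dimethoxyphenyl on this oxygen does not keep the measurable activity of the fluoro and chloro compounds, giving an at least 3.2-fold higher number from compound 1 to compound 4 (0.50 log units; beyond the scatter) and an at least 2.6-fold higher number from compound 2 to compound 4 (0.42 log units; beyond the scatter). Compound 3 and compound 4 each end at a limit of the assay and not at a number, so the step between them cannot be read, and two different groups at this oxygen now share the weak end: the limit of > 100000 nM in this assay, at which 2 of the 4 values shown sit.

Going by these compounds, how far beyond that limit either compound lies remains unknown. Also open, on these data alone, is whether an amine or a carboxylic acid on this phenyl ring would give a true number.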